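Fluoro for chloro, from compound 3 to compound 4

The source may hold more compounds than are shown below. What is called first, only, known or untested is meant among the compounds shown, and "the series" means these compounds.

Measured so far in a functional assay on U-251 cells (Homo sapiens); on this read-out higher numbers stand for weaker inhibition of growth and lower numbers for stronger inhibition of growth:
- compound 1 `O=S(=O)(/C=C/c1ccc(F)cc1F)Cc1ccc(Nc2ncnc3ccccc23)cc1` gives > 100000 nM as a limit of the assay
- compound 2 `O=S(=O)(/C=C/c1ccc(Cl)cc1Cl)Cc1ccc(Nc2ncnc3cc(Cl)ccc23)cc1` gives 53000 nM as a number
- compound 3 `O=S(=O)(/C=C/c1ccc(F)cc1Cl)Cc1ccc(Nc2ncnc3cc(Cl)ccc23)cc1` gives 2000 nM as a number

Of the two actual numbers, compound 3 has the lower one at 2000 nM in this series. Compound 1 shows only a limit.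

Next comes compound 4 `O=S(=O)(/C=C/c1ccc(F)cc1F)Cc1ccc(Nc2ncnc3cc(Cl)ccc23)cc1` with the change fluoro in place of chloro on an aromatic carbon in which fluoro replaces chloro on an aromatic carbon, ortho to a large group. Going by the values given here, one measured step bears on this: a 27-fold lower number from compound 2 to compound 3 (1.42 log units; beyond the scatter) for the same exchange at another carbon of that ring. That step was large, but its direction may not carry over to a different carbon, so a wide range is kept. The expected result is a 1.5-fold higher number from compound 3 to compound 4 (0.18 log units; within the scatter) with no firm direction. Compound 4 is estimated in this assay at 3000 nM with 400 nM to 30000 nM as its range.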

Compound 4, concentration for 50% growth inhibition: > 100000 nM
Compound 4: a limit, no number (the forecaster's own chance of this, stated with the estimate: 10%); middle value at least 33-fold (1.52 log units) away from the limit.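

In this assay, fluoro for chloro on the carbon ortho to a large group gives an at least 50-fold higher number from compound 3 to compound 4 (1.69 log units; beyond the scatter), against a 27-fold lower number from compound 2 to compound 3 (1.42 log units; beyond the scatter) for the same exchange at another carbon of that ring, so the outcome of this exchange depends on the carbon. Compound 4 holds a limit, not a number, so its step has only a floor: the limit of > 100000 nM in this assay, at which 2 of the 4 values shown sit. Exchanging both chloro groups gives an at least 1.8-fold higher number from compound 2 to compound 4 (0.27 log units; that floor lies within the scatter), a floor that does not separate the two compounds, and the step from compound 1 to compound 4 cannot be read.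

Open, going by these compounds, is whether bromo, methyl or methoxy on this carbon would keep the growth inhibition seen with chloro.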